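The source may hold more compounds than are shown below. What is called first, only, known or untested is meant among the compounds shown, and "the series" means these compounds.

Compound 1 `COc1ccc(-c2nnc([S+](C)[O-])n2C)cc1`: > 100 mg/kg (a limit)
Compound 2 `Cn1nc(-c2ccccc2)nc1S(C)(=O)=O`: > 200 mg/kg (a limit)
Compound 3 `Cn1nc(-c2ccc(Cl)cc2)nc1S(C)(=O)=O`: > 200 mg/kg (a limit)
Compound 4 `Cn1nc(-c2cccc(F)c2)nc1S(C)(=O)=O`: not yet measured

All of these results come from a functional assay on the whole organism for antagonist activity, with Mus musculus as the target, in the maximal electroshock model (a lower number here means that less compound is needed, a higher number that more compound is needed for the effect), and none of them is an exact number. Compound 2 has no measured dose, only the limit > 200 mg/kg. It shares this with compound 3, as the limit of > 200 mg/kg in this assay, at which 2 of the 3 values shown sit, shows, while compound 1 alone sits at the limit of > 100 mg/kg in this assay, at which 1 of the 3 values shown sits.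

Compound 4 keeps the core of compound 2 and differs in one place: fluoro in place of hydrogen on an aromatic carbon. The fluoro sits on an aromatic carbon, meta to a large group.

The closest measured comparison is another single replacement of hydrogen on an aromatic carbon, this time by chloro: a step that the two limits leave unreadable from compound 2 to compound 3. Both ends of that step are limits, so it gives neither a size nor a direction. Compound 3, which carries the chloro, also sits at a limit, > 200 mg/kg.

With no exact dose yet seen in this assay, no step beyond the scatter is expected, and a report of only a limit is the likeliest outcome. The expected step is a number no higher from compound 2 to compound 4 (the limit leaves the size open). For compound 4 the estimated value is 200 mg/kg, with an expected range from 80 mg/kg to 400 mg/kg.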

Compound 4, dose for half-maximal effect: > 100 mg/kg
Compound 4 ended at the assay's limit; the forecaster's own chance of this, stated with the estimate: 70%; the middle value is on the limit's open side.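

Among the compounds shown here, compound 2 and compound 4 are both reported only as limits, so no step between them can be read from this assay, in either size or direction. The compounds shown leave open what exact dose any of them needs in this assay, and so whether fluoro or chloro in place of hydrogen changes that dose at all.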